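This account rests on a few compounds, and the source may have more. Where it says the series, first, only, none or still open, it means among the compounds named here.

Measured in a functional assay on HepG2 cells (Homo sapiens) for inhibition, read by MTT assay; a higher number here means a weaker inhibitor, a lower number a stronger inhibitor:
- compound 1 `COc1cc2ncnc(Nc3ccc(NC(=O)c4ccc(C)cc4)cc3)c2cc1OC`: 25000 nM
- compound 2 `COc1cc2ncnc(Nc3ccc(NC(=O)c4ccccc4OC)cc3)c2cc1OC`: > 100000 nM (a limit of the assay, not a number)
- compound 3 `CCc1ccc(C(=O)Nc2ccc(Nc3ncnc4cc(OC)c(OC)cc34)cc2)cc1`: 72000 nM

Among the two actual numbers, compound 3 at 72000 nM holds the higher one, and the comparison with its nearest neighbour reads a 2.9-fold higher number from compound 1 to compound 3 (0.46 log units; beyond the scatter). Compound 2 reports only a limit, > 100000 nM.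

The next structure, compound 4 `COc1cc2ncnc(Nc3ccc(NC(=O)c4ccccc4F)cc3)c2cc1OC`, carries 2-fluorophenyl in place of 4-ethylphenyl on a carbonyl carbon. Two measured steps change this same group. The closest counterpart to the entering group is the 2-methoxyphenyl of compound 2, and the step to compound 3 reads an at least 1.3-fold lower number from compound 2 to compound 3 (0.14 log units; that floor lies within the scatter). Replacing 4-methylphenyl with that group gave an at least 4.0-fold higher number from compound 1 to compound 2 (0.60 log units; beyond the scatter). These steps suggest a weak compound, but neither measures 2-fluorophenyl itself, so no shift beyond the scatter is expected in this assay. The expected step is a 1.0-fold lower number from compound 3 to compound 4 (0.01 log units; within the scatter). Compound 4 is expected at 70000 nM, with an estimated range of 25000 nM to 160000 nM.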

Compound 4, half-maximal inhibitory concentration: 13000 nM
For compound 4 the middle estimate is 5.4-fold (0.73 log units) above the measured one; the measured number lies below the stated range.
By their numbers in this assay, from the lowest: compounds 4 and 1 (each within the scatter of the next); then compound 3. At a limit, above all of these: compound 2.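

In this assay, the carbonyl carbon's aryl group proved able to move the number down as well as up: 2-fluorophenyl in place of 4-ethylphenyl gave a 5.5-fold lower number from compound 3 to compound 4 (0.74 log units; beyond the scatter), while 2-fluorophenyl in place of 4-methylphenyl gave a 1.9-fold lower number from compound 1 to compound 4 (0.28 log units; within the scatter). A group at the 2-position of this phenyl therefore need not leave the compound weak, as fluoro in place of methoxy on an aromatic carbon gave an at least 7.6-fold lower number from compound 2 to compound 4 (0.88 log units; beyond the scatter). Compound 2 stands at a limit of the assay, not a number: the limit of > 100000 nM in this assay, at which 1 of the 4 values shown sits.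

As far as these compounds go, it remains open how a 4-fluorophenyl, 2-chlorophenyl or 2-aminophenyl group would read on this carbonyl carbon. From the compounds shown here alone, with only these four compounds, what sets the gap between fluoro and methoxy also stays open.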